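A few compounds are considered here, and "the series" means these few. Any claim that something is new, unique, unknown or untested is made for them only; others in the source may bear on it.

Working notes on the series.

The shared core carries a tertiary amine on a saturated chain carbon bound to an aromatic carbon, and the three measured compounds differ only in the two groups on that amine nitrogen. Compound 1 `CCN(Cc1c(C(F)(F)F)nc2n(-c3c(C)cc(C)cc3C)c(Cl)cn12)CC1CC1` gives 9 nM in an assay on cells for displacement of a labelled ligand from corticotropin-releasing factor receptor 1 (Homo sapiens), with a stated time of 100 min; a higher number here means a weaker inhibitor, a lower number a stronger inhibitor. Compound 2 `CCCN(CCC(F)(F)F)Cc1c(C(F)(F)F)nc2n(-c3c(C)cc(C)cc3C)c(Cl)cn12` gives 12 nM in this assay; compound 3 `C=C(C)CN(CC)Cc1c(C(F)(F)F)nc2n(-c3c(C)cc(C)cc3C)c(Cl)cn12` gives 67 nM in this assay. Compound 2 thus sits second highest of the three numbers: its nearest neighbour is compound 1, with a 1.3-fold higher number from compound 1 to compound 2 (0.12 log units; within the scatter), and its furthest is compound 3, with a 5.6-fold higher number from compound 2 to compound 3 (0.75 log units; beyond the scatter). The other step, a 7.4-fold higher number from compound 1 to compound 3 (0.87 log units; beyond the scatter), is of similar size.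

Compound 4 `CCCN(Cc1ccc(Cl)cc1)Cc1c(C(F)(F)F)nc2n(-c3c(C)cc(C)cc3C)c(Cl)cn12` is not yet measured. It arises from compound 2 through (4-chlorophenyl in place of 2,2,2-trifluoroethyl on a saturated chain carbon bound to an amine nitrogen). Within the data shown here, no measured step alters this group in the same way; the step from compound 1 to compound 2 shows that exchanging both amine substituents can stay within the scatter, while the steps to compound 3 show that a small change on one of them can cost modestly. A step in this assay of small to modest size toward a higher number, or none beyond the scatter, is therefore expected, a 2.5-fold higher number from compound 2 to compound 4 (0.40 log units; beyond the scatter). The estimate for compound 4 is 30 nM, with a range from 8 nM to 120 nM.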

Compound 4, inhibition constant: 28 nM
The estimate for compound 4 lay 1.1-fold (0.03 log units) above the measured number; measured number inside the range.
By their numbers in this assay, from the lowest: compounds 1 and 2 (each within the scatter of the next); then compound 4; then compound 3.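

The 2,2,2-trifluoroethyl end of the chain on compound 2 can be exchanged for 4-chlorophenyl, placing a six-membered aromatic ring on a saturated chain carbon bound to an amine nitrogen, at only a modest cost in this assay: a 2.3-fold higher number from compound 2 to compound 4 (0.37 log units; beyond the scatter). Among these compounds, the earlier compounds carried no aromatic ring on the amine nitrogen, so this is the first sign that the position accepts one, with compound 4 still at 28 nM. Nothing available explains the size of this step.

The compounds shown leave open how much of the step belongs to the chlorine and how much to the ring, as neither an unsubstituted benzyl nor a 4-methoxybenzyl group stands among them. Also open, going by these compounds, is whether a pyridine ring or a carboxylic acid would be accepted at the same place.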